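Compound 3 and the move to a hydroxycyclohexyl group

A few compounds are considered here, and "the series" means these few. Any claim that something is new, unique, unknown or untested is made for them only; others in the source may bear on it.

Compound 1 `O=C(c1nc2sccn2c1Cl)N1CCN(C2CCCC2)C(=O)C1`: > 10000 nM
Compound 2 `Cc1csc2nc(C(=O)N3CCN(C4CCCC4)C(=O)C3)c(Cl)n12`: > 10000 nM
Compound 3 `O=C(c1nc2scc(C3CC3)n2c1Cl)N1CCN(C2CCCC2)C(=O)C1`: > 10000 nM

In an ADME assay on Huh-7 cells (Homo sapiens) for cytotoxicity (a lower number here means that less compound is tolerated, a higher number that more compound is tolerated), compound 3 gives > 10000 nM, which is a limit and not a number. Compounds 1 and 2 also give only limits, so all three stand together at the limit of > 10000 nM in this assay, at which 3 of the 3 values shown sit.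

Compound 4 `O=C(c1nc2scc(C3CC3)n2c1Cl)N1CCN([C@H]2CC[C@H](O)CC2)C(=O)C1` differs from compound 3 in one place: 4-hydroxycyclohexyl in place of cyclopentyl on an amide-type nitrogen in a ring. The change puts 4-hydroxycyclohexyl in place of cyclopentyl on an amide-type nitrogen in a ring.

Three measured steps exist: a step that the two limits leave unreadable from compound 1 to compound 2, a step that the two limits leave unreadable from compound 1 to compound 3 and a step that the two limits leave unreadable from compound 2 to compound 3. Each of them swaps a group on an aromatic carbon, and none touches the cyclopentyl group. Their sizes cannot be read, so they give only weak guidance for this change.

No step beyond the usual scatter is expected in this assay, and no direction can be assigned with confidence. The expected change is a step that the limit leaves unreadable from compound 3 to compound 4. For compound 4 the estimated half-maximal cytotoxic concentration is 15000 nM, with an expected range from 8000 nM to 40000 nM.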

Compound 4, half-maximal cytotoxic concentration: > 10000 nM
Compound 4 gave a limit, no number (the forecaster's own chance of this, stated with the estimate: 90%); the middle value is on the limit's open side.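

In this assay compound 4 gives > 10000 nM, which is a limit and not a number. Compound 3 also stands at a limit, so no step can be read between compound 3 and compound 4. The compounds shown leave open where any true half-maximal cytotoxic concentration lies, and whether these group changes shift it at all: the limit of > 10000 nM in this assay, at which 4 of the 4 values shown sit.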